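This account rests on a few compounds, and the source may have more. Where it says the series, first, only, none or still open, it means among the compounds named here.

In an ADME assay on MT4 cells (Homo sapiens) for cytotoxicity, read by MTT assay, with a stated time of 4 days (a lower number here means that less compound is tolerated, a higher number that more compound is tolerated), three related compounds have been measured. Compound 1 `COc1c(-c2cccc(F)c2)oc2ccc(NC(C)=O)cc2c1=O` gives 210000 nM. Compound 2 `COc1c(-c2ccc(F)cc2)oc2ccc(NC(C)=O)cc2c1=O` gives 317000 nM. Compound 3 `COc1c(-c2cccc(F)c2)oc2ccc(N)cc2c1=O` gives 113000 nM.

Compound 1 and compound 2 differ only in the position of the fluorine on the pendant ring: 4-fluorophenyl in place of 3-fluorophenyl on an aromatic carbon. That change brought a 1.5-fold higher number from compound 1 to compound 2 (0.18 log units; within the scatter), so the two compounds are tolerated to a similar degree.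

Compound 3 has a different core from compound 1: hydrogen in place of acetyl on a nitrogen on an aromatic ring. This change brought a 1.9-fold lower number from compound 1 to compound 3 (0.27 log units; within the scatter).

Compound 4 `COc1c(-c2ccc(F)cc2)oc2ccc(N)cc2c1=O` has not yet been measured in this assay. It relates to compound 3 exactly as compound 2 relates to compound 1: 4-fluorophenyl in place of 3-fluorophenyl on an aromatic carbon. The surroundings of the change are the same in both pairs, so it is the same change made on a different core.

Because the earlier instance of this change gave a 1.5-fold higher number from compound 1 to compound 2 (0.18 log units; within the scatter), a step of similar size is expected from compound 3 to compound 4, namely a 1.5-fold higher number from compound 3 to compound 4 (0.18 log units; within the scatter). On that basis compound 4 is estimated to give 170000 nM in this assay, most likely between 90000 nM and 320000 nM.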

Compound 4, half-maximal cytotoxic concentration: 141000 nM
Compound 4: middle estimate off by 1.2-fold (0.08 log units), on the high side; the measured number falls inside the stated range.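

Replacing 3-fluorophenyl with 4-fluorophenyl gave a 1.2-fold higher number from compound 3 to compound 4 (0.10 log units; within the scatter) in this assay, and this small step carried over from one core to the other: the same change on two cores in this assay, a 1.5-fold higher number (0.18 log units; within the scatter) from compound 1 to compound 2 and a 1.2-fold higher number (0.10 log units; within the scatter) from compound 3 to compound 4, 1.2-fold (0.08 log units) apart, within the scatter of two such steps

Replacing the acetyl on the nitrogen with hydrogen gave a 2.2-fold lower number from compound 2 to compound 4 (0.35 log units; beyond the scatter), and this step also carried over: the same change on two cores in this assay, a 1.9-fold lower number (0.27 log units; within the scatter) from compound 1 to compound 3 and a 2.2-fold lower number (0.35 log units; beyond the scatter) from compound 2 to compound 4, 1.2-fold (0.08 log units) apart, within the scatter of two such steps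

Within these four compounds, each change therefore had much the same effect whichever form of the other group was present, but each comparison rests on only two pairs, so this does not show that the steps would hold on other cores, and it does not explain why they arise.

The compounds shown leave open how a phenyl ring without fluorine, or with chlorine in its place, would compare. They also leave open what a longer acyl chain, such as propionyl, or a methanesulfonyl group on the nitrogen would do to the cell tolerance of this series.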